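A few compounds are considered here, and "the series" means these few. Any claim that something is new, unique, unknown or untested is made for them only; others in the source may bear on it.

Measured compounds:
compound 1 `Cc1nc(C)n(CC(=O)N2CCN(c3sc(C(F)(F)F)nc3-c3nc4ccc(OC5CNC5)cc4[nH]3)C[C@H]2C)n1` — in a functional assay on Venous blood for antagonist activity at C-X-C chemokine receptor type 3 (Homo sapiens), read by flow cytometry, with a stated time of 30 min, in the presence of a further agent that is not named here (a lower number here means a stronger inhibitor, a higher number a weaker inhibitor), compound 1 gives 580 nM
compound 2 `Cc1nc(C)n(CC(=O)N2CCN(c3sc(C(F)(F)F)nc3-c3nc4c(C(F)(F)F)cccc4[nH]3)C[C@H]2C)n1` — in this assay compound 2 gives 747 nM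

Of these two numbers, compound 1 has the lower one, yet its gap to compound 2 lies within the scatter, so neither can be called the stronger inhibitor. Compound 3 `Cc1nc(C)n(CC(=O)N2CCN(c3sc(C(F)(F)F)nc3-c3nc4ccc(OC5COC5)cc4[nH]3)C[C@H]2C)n1` is not yet measured. Within the data shown here, it differs from compound 1 in one place: oxetan-3-yl in place of azetidin-3-yl on an oxygen on an aromatic ring No step between measured compounds is available, so the expectation rests on this change alone. For compound 3 a small rise in the number is expected, a 1.7-fold higher number from compound 1 to compound 3 (0.24 log units; within the scatter), near the edge of the scatter. The estimate for compound 3 is 1000 nM, within 400 nM to 2500 nM.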

Compound 3, half-maximal inhibitory concentration: 1480 nM
The estimate for compound 3 lay 1.5-fold (0.17 log units) below the measured number; the range from low to high includes it.
By their numbers in this assay, from the lowest: compounds 1, 2 and 3 (each within the scatter of the next, the first and the last beyond it).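

In this assay, on an oxygen on an aromatic ring, oxetan-3-yl in place of azetidin-3-yl gives a 2.6-fold higher number from compound 1 to compound 3 (0.41 log units; beyond the scatter). Among these compounds, this is the first step beyond the usual scatter, so this position does respond to a change in the group it carries, even though the ring size and heavy-atom count stay the same and only the ring nitrogen with its hydrogen-bond donor is exchanged for oxygen. Nothing measured here explains the step. Still open, as far as these compounds go, is how cyclobutyl, with an all-carbon ring, or 1-methylazetidin-3-yl would read at this position. Either would help show whether the ring nitrogen or its hydrogen accounts for the difference.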